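Fluorine on the benzamide ring: a step within the measured limit

The source may report more compounds than this note shows. Statements on the series, on what has been measured and on what is new or still open speak of the compounds shown alone.

Compound 1 `O=C(NC/C=C\Cn1ccc(=O)[nH]c1=O)c1ccccc1` gives > 100000 nM in this study.
Compound 2 `Cc1cn(C/C=C\CNC(=O)c2ccccc2)c(=O)[nH]c1=O` gives > 100000 nM.
Compound 3 `Nc1ccn(C/C=C\CNC(=O)c2ccccc2)c(=O)n1` gives > 100000 nM.

The three compounds share one core and were tested in a functional assay on SW-620 cells (Homo sapiens) for cytotoxicity, read by MTT assay, with a stated time of 72 h; a higher number here means a weaker inhibitor, a lower number a stronger inhibitor. For compound 1 the value > 100000 nM is a limit of the assay and not a number. For compound 2 the value > 100000 nM is likewise a limit. For compound 3 the value > 100000 nM is a limit as well, so compound 3 stands only at the edge of what the assay can report, together with the other two. Among the measured compounds shown here, the one step that can be traced, a step that the two limits leave unreadable from compound 1 to compound 2, cannot be sized.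

Compound 4 `Nc1ccn(C/C=C\CNC(=O)c2ccc(F)cc2)c(=O)n1` differs from compound 3 by fluoro in place of hydrogen on an aromatic carbon. For the measured compounds named here, no measured step bears on this change, and the only evidence is the limit of > 100000 nM in this assay, at which 3 of the 3 values shown sit. The step that the limit leaves unreadable from compound 3 to compound 4 is therefore expected to stay within the scatter, with compound 4 expected around 150000 nM, between 50000 nM and 500000 nM, most likely again reported as a limit.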

Compound 4, half-maximal inhibitory concentration: > 100000 nM
Compound 4: a limit, no number; the forecaster's own chance of this, stated with the estimate: 85%; the middle value lies beyond the limit too.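

Compound 3 and compound 4 both stand at a limit of the assay and not at a number, so no step between them can be read: the limit of > 100000 nM in this assay, at which 4 of the 4 values shown sit.

The compounds shown leave open whether any change to the shared core would give a measured number instead of a limit.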